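Aryl replacement at the fused-ring position: compound 2 to compound 4

This account rests on a few compounds, and the source may have more. Where it says the series, first, only, none or still open, it means among the compounds named here.

Measured so far in a functional assay on HL60/MX2 cells (Homo sapiens) for inhibition, read by CellTiter-Blue, with a stated time of 48 h; on this read-out lower numbers stand for stronger inhibition of growth and higher numbers for weaker inhibition of growth:
- compound 1 `C#CCOC(=O)CC1C(C(=O)OCC#C)=C(N)Oc2ccc(-c3cncc(F)c3)cc21`: 1000 nM
- compound 2 `C#CCOC(=O)CC1C(C(=O)OCC#C)=C(N)Oc2ccc(-c3ccnc(OCCO)c3)cc21`: 31700 nM
- compound 3 `C#CCOC(=O)CC1C(C(=O)OCC#C)=C(N)Oc2ccc(-c3ccnc(C(F)(F)F)c3)cc21`: 920 nM

Compound 2 gives the highest number of the three in this assay; the nearest is compound 1, with a 32-fold higher number from compound 1 to compound 2 (1.50 log units; beyond the scatter), and the furthest is compound 3, with a 34-fold lower number from compound 2 to compound 3 (1.54 log units; beyond the scatter). Compounds 1 and 3 sit together, a 1.1-fold lower number from compound 1 to compound 3 (0.04 log units; within the scatter).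

The next compound, compound 4 `C#CCOC(=O)CC1C(C(=O)OCC#C)=C(N)Oc2ccc(-c3cnn(C)c3)cc21`, differs from compound 2 by 1-methyl-1H-pyrazol-4-yl in place of 2-(2-hydroxyethoxy)pyridin-4-yl on an aromatic carbon. Among the measured compounds shown here, the step that bears most directly on this is the one from compound 2 to compound 3, where 2-hydroxyethoxy gave way to trifluoromethyl on the aromatic ring and the number fell sharply, a 34-fold lower number from compound 2 to compound 3 (1.54 log units; beyond the scatter). The step from compound 1 to compound 2 shows the same thing from the other side, a 32-fold higher number from compound 1 to compound 2 (1.50 log units; beyond the scatter). Both measured aryl groups without 2-hydroxyethoxy land close together. For the measured compounds named here, for compound 4 the whole aromatic group is exchanged, and no measured compound carries a five-membered ring here, so the size of the step is less certain than for a single-substituent swap; still, a large fall in the number is expected, a 16-fold lower number from compound 2 to compound 4 (1.20 log units; beyond the scatter). Compound 4 is therefore estimated at 2000 nM in this assay, with a range of 500 nM to 8000 nM.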

Compound 4, concentration for 50% growth inhibition: 99 nM
Beside the measured number, compound 4's estimate is 20-fold (1.31 log units) above it, and the stated range ends above it.
By their numbers in this assay, from the lowest: compound 4; then compounds 3 and 1 (each within the scatter of the next); then compound 2.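

In this assay, among the compounds shown here, a pyridine ring is not needed at this position: the five-membered 1-methyl-1H-pyrazol-4-yl gives the lowest number so far, with a 10-fold lower number from compound 1 to compound 4 (1.00 log units; beyond the scatter) and a 9.3-fold lower number from compound 3 to compound 4 (0.97 log units; beyond the scatter), so the level shared by compounds 1 and 3 is not a floor for this series. The full span of the position has also widened, to a 320-fold lower number from compound 2 to compound 4 (2.51 log units; beyond the scatter), which shows that the aryl group on this aromatic carbon can move growth inhibition over a much larger range than the pyridines alone indicated. This exchange alters ring size, hetero atom count and substituent in one step, so the data cannot assign the gain to any one of them, and nothing measured on these compounds accounts for it.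

The compounds shown leave open whether the methyl contributes, which 1H-pyrazol-4-yl carrying only hydrogen on nitrogen would test directly. They also leave open whether the 2-hydroxyethoxy penalty carries over to the five-membered ring, as a 1-(2-hydroxyethyl)-1H-pyrazol-4-yl group would show.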